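A few compounds are considered here, and "the series" means these few. Any claim that something is new, unique, unknown or untested is made for them only; others in the source may bear on it.

Measured compounds:
Compound 1 `Nc1scc(CN2CCN(C3CCCCC3)CC2)c1C(=O)c1ccc(Cl)cc1` gives 1.1 nM in an assay on CHO cells for displacement of a labelled ligand from adenosine receptor A1 (Homo sapiens); a lower number here means tighter binding, a higher number weaker binding.
Compound 2 `Nc1scc(CN2CCN(c3ccccc3)CC2)c1C(=O)c1ccc(Cl)cc1` gives 1 nM in this assay.
Compound 3 `Nc1scc(CN2CCN(c3ccc(Cl)cc3)CC2)c1C(=O)c1ccc(Cl)cc1` gives 1.1 nM in this assay.

Compound 3 stands level with compound 1 at the digits shown, and these two carry the highest numbers of the three; its nearest neighbour is compound 1, its furthest compound 2, with a 1.1-fold higher number from compound 2 to compound 3 (0.04 log units; within the scatter). All three values lie within the scatter of one another.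

Compound 4 `Nc1scc(CN2CCN(c3ncccn3)CC2)c1C(=O)c1ccc(Cl)cc1` differs from compound 3 by pyrimidin-2-yl in place of 4-chlorophenyl on an amine nitrogen in a ring. Going by the values given here, no measured step places a pyrimidin-2-yl on this ring nitrogen, so the change is not covered directly. Among the compounds with values here, the steps that bear on the same position are a 1.1-fold lower number from compound 1 to compound 2 (0.04 log units; within the scatter), no change at the digits printed from compound 1 to compound 3 (within the scatter) and a 1.1-fold higher number from compound 2 to compound 3 (0.04 log units; within the scatter): cyclohexyl, phenyl and 4-chlorophenyl on that nitrogen all gave the same number within the scatter. As far as these compounds go, on that basis no step beyond the scatter is expected in this assay in either direction, with the range widened because the group itself is untested. Compound 4 is expected at 1.5 nM (range 0.5 nM to 5 nM), meaning an estimated step of a 1.4-fold higher number from compound 3 to compound 4 (0.13 log units; within the scatter).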

Compound 4, dissociation constant: 1.1 nM
For compound 4 the middle estimate is 1.4-fold (0.13 log units) above the measured one; low and high end bracket the measured number.
By their numbers in this assay, from the lowest: compounds 2, 1, 3 and 4 (each within the scatter of the next).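

With pyrimidin-2-yl on the amine nitrogen in a ring, this assay shows no step beyond the scatter from any earlier compound (no change at the digits printed from compound 3 to compound 4 (within the scatter); a 1.1-fold higher number from compound 2 to compound 4 (0.04 log units; within the scatter); no change at the digits printed from compound 1 to compound 4 (within the scatter)). The position therefore accepts a six-membered aromatic ring with 2 hetero atoms and 2 hydrogen-bond acceptors as well as the carbon-only groups cyclohexyl, phenyl and 4-chlorophenyl, with all four compounds level within the scatter. No measurement here offers an explanation for this flat result.

As far as these compounds go, whether a longer chain, a carboxylic acid or a basic amine on this ring nitrogen would move the number remains open. Only this one position varies across the four compounds, so how changes elsewhere on the shared core, such as replacing the chloro on the aryl ketone, would read in this assay is also unresolved.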